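Swapping tert-butyl for hydroxymethyl: compound 3 to compound 4

This account rests on a few compounds, and the source may have more. Where it says the series, first, only, none or still open, it means among the compounds named here.

In a functional assay on B16 cells (Mus musculus) for inhibition (a higher number here means a weaker inhibitor, a lower number a stronger inhibitor), compound 1 (`NC(=S)Nc1ccc(O)cc1`) gives 6300 nM as its half-maximal inhibitory concentration and compound 2 (`COc1ccc(NC(N)=S)cc1`) gives 5600 nM on the same read-out. Methyl in place of hydrogen on an oxygen on an aromatic ring shows a 1.1-fold lower number from compound 1 to compound 2 (0.05 log units; within the scatter) and this is the only measured step.

Compound 3 (`CC(C)(C)c1ccccc1NC(N)=S`) has no number and stands only at the limit > 10000 nM of this assay.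

Compound 4 (`NC(=S)Nc1ccccc1CO`) differs from it by one exchange, hydroxymethyl in place of tert-butyl on an aromatic carbon is the full count of that change.

For the measured compounds named here, no measured step covers this exchange, and the one step available concerns a different group, so it bears only weakly. Compound 1 at 6300 nM is the nearest kind of number to lean on, so a modest move towards a lower number is expected. The estimated move in this assay is an at least 1.4-fold lower number from compound 3 to compound 4 (0.15 log units; that floor lies within the scatter) on this reading. The estimated value for compound 4 is 7000 nM with 2500 nM to 20000 nM as its expected range.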

Compound 4, half-maximal inhibitory concentration: > 10000 nM
Compound 4: only a limit was reported; the forecaster's own chance of this, stated with the estimate: 35%; middle value at least 1.4-fold (0.15 log units) from the limit.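

Compound 3 and compound 4 both stand at a limit rather than a number, so the step between them cannot be read: the limit of > 10000 nM in this assay, at which 2 of the 4 values shown sit.

The compounds shown leave open whether hydroxymethyl in place of tert-butyl on an aromatic carbon changes the number at all in this assay.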